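Iodo in Place of Ethynyl on Two Nucleoside Cores

The compounds below may be only part of what the source reports. "The series", "measured", "known", "first", "only" and "open" are said of these compounds alone.

Three compounds have been measured in a functional assay on HCT-116 cells (Homo sapiens), read by MTT assay, with a stated time of 72 h; on this read-out higher numbers stand for weaker inhibition and lower numbers for stronger inhibition:

Compound 1 `Cc1ncnc2c1c(I)cn2[C@@H]1O[C@H](CO)[C@@H](O)[C@H]1O` gives 7570 nM.
Compound 2 `C#Cc1cn([C@@H]2O[C@H](CO)[C@@H](O)[C@H]2O)c2ncnc(C)c12` gives > 20000 nM, which is a limit of the assay, not a number.
Compound 3 `C#Cc1cn([C@@H]2O[C@H](CO)[C@@H](O)[C@H]2O)c2nc(C)nc(N)c12` gives > 20000 nM, again a limit of the assay rather than a number.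

Compound 1 differs from compound 2 by iodo in place of ethynyl on an aromatic carbon. This change brought an at least 2.6-fold lower number from compound 2 to compound 1 (0.42 log units; beyond the scatter), and the true size of that step is bounded by the limit of > 20000 nM in this assay, at which 2 of the 3 values shown sit. Compound 2 and compound 3 have different cores; the difference between the two cores is not broken down here.

Compound 4 `Cc1nc(N)c2c(I)cn([C@@H]3O[C@H](CO)[C@@H](O)[C@H]3O)c2n1` has not yet been measured. It differs from compound 3 by iodo in place of ethynyl on an aromatic carbon, the same change at the same place as between compound 2 and compound 1. Compound 4 is therefore expected to show a step of an at least 2.2-fold lower number from compound 3 to compound 4 (0.34 log units; beyond the scatter) in this assay, an expectation resting on an at least 2.6-fold lower number from compound 2 to compound 1 (0.42 log units; beyond the scatter). Because that step is known only as a bound set by the limit of > 20000 nM in this assay, at which 2 of the 3 values shown sit, the expectation is loose, and compound 4 may itself give only a limit. Compound 4 is estimated at 9000 nM, between 3000 nM and 30000 nM.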

Compound 4, half-maximal inhibitory concentration: > 20000 nM
Compound 4: only a limit was reported; the forecaster's own chance of this, stated with the estimate: 35%; at least 2.2-fold (0.34 log units) between middle value and limit.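

No step can be read from compound 3 to compound 4 in this assay, because both compounds give only a limit: the limit of > 20000 nM in this assay, at which 3 of the 4 values shown sit. The compounds shown leave open how large the change from ethynyl to iodo is on the core shared by compound 3 and compound 4, and whether it matches the step on the core of compound 1.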